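Two High Limits and One Added Cyano Group

This account rests on a few compounds, and the source may have more. Where it says the series, first, only, none or still open, it means among the compounds named here.

- Compound 1 `Cc1cc(OCC(=O)Nc2ccc(C#N)cc2)nc(Nc2ccc(C#N)cc2)n1` gives > 325000 nM (a limit)
- Compound 2 `Cc1cnc(Nc2ccc(C#N)cc2)nc1OCC(=O)Nc1ccccc1F` gives > 331000 nM (a limit)

In an ADME assay on MT4 cells (Homo sapiens) for cytotoxicity, read by MTT assay, with a stated time of 5 days (on this read-out higher numbers stand for lower toxicity in this test and lower numbers for higher toxicity in this test), compound 2 gives > 331000 nM, which is a limit of the assay and not a number. Compound 1 gives > 325000 nM in this assay, and this too is a limit. Among the compounds with values here, no exact value is therefore known for either compound, and no measured pair shows the effect of a single change.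

Compound 3 `Cc1cnc(Nc2ccc(C#N)cc2)nc1OCC(=O)Nc1ccc(C#N)cc1F` differs from compound 2 in one place: cyano in place of hydrogen on an aromatic carbon. A cyano group takes the place of a hydrogen on an aromatic carbon, meta to a fluoro group and para to a large group, so that 2-fluorophenyl becomes 4-cyano-2-fluorophenyl.

Compound 1 also carries a cyano group on its amide side and still gives > 325000 nM, so no step beyond the scatter is expected in this assay. Any shift would most likely be toward lower numbers. The estimated at least 1.3-fold lower number from compound 2 to compound 3 (0.12 log units; that floor lies within the scatter) is small, and another limit is quite likely. Compound 3 is estimated at 250000 nM, with an expected range from 40000 nM to 320000 nM.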

Compound 3, half-maximal cytotoxic concentration: > 310000 nM
Compound 3: only a limit was reported (the forecaster's own chance of this, stated with the estimate: 65%); at least 1.2-fold (0.09 log units) between middle value and limit.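

Compound 3 gives > 310000 nM in this assay, and this is a limit. Within the data shown here, compound 2 also gives only a limit, so no step between compound 2 and compound 3 can be read. The compounds shown leave open what their exact values are and whether the added cyano group changes the read-out at all.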